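This account rests on a few compounds, and the source may have more. Where it says the series, first, only, none or still open, it means among the compounds named here.

Measured so far:
- Compound 1 `CN(C)c1ccc(/C=C(/SCc2ccc(Cl)cc2Cl)C(=O)c2ccc(Cl)cc2)cc1` gives 50000 nM in a functional assay on DU-145 cells (Homo sapiens) for inhibition, read by trypan blue exclusion, with a stated time of 96 h; a lower number here means a stronger inhibitor of growth, a higher number a weaker inhibitor of growth.
- Compound 2 `CN(C)c1ccc(/C=C(/Sc2ccc(Br)cc2)C(=O)c2ccc(Cl)cc2)cc1` gives only an assay limit, > 100000 nM, in this assay.

Compound 2 thus sits at the limit of > 100000 nM in this assay, at which 1 of the 2 values shown sits, and has no definite number. Compound 3 `O=C(/C(=C\c1ccc(O)cc1O)Sc1ccc(Br)cc1)c1ccc(Cl)cc1` differs from it by 2,4-dihydroxyphenyl in place of 4-(dimethylamino)phenyl on a double-bonded chain carbon bound to a double-bonded chain carbon. For the measured compounds named here, the single measured step, an at least 2.0-fold higher number from compound 1 to compound 2 (0.30 log units; that floor lies within the scatter), changes the group on the sulfur, not this position, so no measured step bears on the present change. With compound 2 at the limit, compound 3 is expected to remain near it, with an estimated 100000 nM and a range from 30000 nM to 300000 nM. The step expected, a number no higher from compound 2 to compound 3 (the limit leaves the size open), is therefore essentially none beyond the scatter.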

Compound 3, concentration for 50% growth inhibition: 50000 nM
Compound 3: the middle estimate sits 2.0-fold (0.30 log units) above what was measured, within the range that was stated.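

For the compounds shown here, the first measured change at this position, 2,4-dihydroxyphenyl in place of 4-(dimethylamino)phenyl on a double-bonded chain carbon bound to a double-bonded chain carbon, gives in this assay an at least 2.0-fold lower number from compound 2 to compound 3 (0.30 log units; that floor lies within the scatter). Going by these compounds alone, the earlier step changed only the group on the sulfur, so this is the first sign that the position can take a different ring without the number rising. The true size of the step stays unknown because compound 2 has only a limit: the limit of > 100000 nM in this assay, at which 1 of the 3 values shown sits.

Going by these compounds, whether a phenyl ring carrying a carboxylic acid would do better here remains open. So does the effect of pairing 2,4-dihydroxyphenyl with 2,4-dichlorobenzyl on the sulfur.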